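Working notes: the imidazole swap from compound 2 to compound 3

This account rests on a few compounds, and the source may have more. Where it says the series, first, only, none or still open, it means among the compounds named here.

Measured so far in a functional assay on HUVEC cells (Homo sapiens), read by scintillation counting and thymidine incorporation, with a stated time of 24 h; on this read-out lower numbers stand for stronger inhibition and higher numbers for weaker inhibition:
- compound 1 `CCC(C)n1ncn(-c2ccc(N3CCN(c4ccc(OC[C@@H]5CO[C@@](CN6CCN(C)CC6)(c6ccc(Cl)cc6Cl)O5)cc4)CC3)cc2)c1=O` gives 396 nM
- compound 2 `CCC(C)n1ncn(-c2ccc(N3CCN(c4ccc(OC[C@@H]5CO[C@@](Cn6cnc(C(F)(F)F)n6)(c6ccc(Cl)cc6Cl)O5)cc4)CC3)cc2)c1=O` gives 270 nM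

For the measured compounds named here, these are the only two numbers, and compound 2 stands within the scatter of compound 1, so neither ranks ahead of the other. Compound 3 `CCC(C)n1ncn(-c2ccc(N3CCN(c4ccc(OC[C@@H]5CO[C@@](Cn6ccnc6C)(c6ccc(Cl)cc6Cl)O5)cc4)CC3)cc2)c1=O` is still unmeasured. It carries 2-methyl-1H-imidazol-1-yl in place of 3-(trifluoromethyl)-1H-1,2,4-triazol-1-yl on a saturated chain carbon bound to a saturated ring carbon. Going by the values given here, one measured step bears on this place: a 1.5-fold lower number from compound 1 to compound 2 (0.17 log units; within the scatter), where 3-(trifluoromethyl)-1H-1,2,4-triazol-1-yl replaced 4-methylpiperazin-1-yl. That single step is thin evidence, but it gives no reason to expect a large change in this assay. The expected result is a 1.1-fold higher number from compound 2 to compound 3 (0.05 log units; within the scatter), with no shift beyond the scatter. For compound 3 the estimate is 300 nM, with an expected range of 110 nM to 800 nM.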

Compound 3, half-maximal inhibitory concentration: 173 nM
Estimate against measurement, compound 3: 1.7-fold (0.24 log units) above; the measured number falls inside the stated range.
By their numbers in this assay, from the lowest: compounds 3, 2 and 1 (each within the scatter of the next, the first and the last beyond it).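

In this assay, the place on a saturated chain carbon bound to a saturated ring carbon now holds a third group, and 2-methyl-1H-imidazol-1-yl in place of 3-(trifluoromethyl)-1H-1,2,4-triazol-1-yl gives a 1.6-fold lower number from compound 2 to compound 3 (0.19 log units; within the scatter), so these two five-membered aromatic rings cannot be separated on this read-out. Against 4-methylpiperazin-1-yl, the same 2-methyl-1H-imidazol-1-yl group gives a 2.3-fold lower number from compound 1 to compound 3 (0.36 log units; beyond the scatter), the only step at this place that clears the scatter, and only modestly. No measurement on hand explains either step.

Still open, as far as these compounds go, is how a plain imidazol-1-yl, a primary amine or a carboxylic acid on the same chain carbon would read in this assay. Also open, from the compounds shown here alone, is whether the step away from 4-methylpiperazin-1-yl holds on any other read-out.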